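Shortening the hydroxycarbamoyl chain of compound 1

The source may report more compounds than this note shows. Statements on the series, on what has been measured and on what is new or still open speak of the compounds shown alone.

compound 1 `COc1cc2c(Oc3ccc(NC(=O)c4nn(-c5ccccc5)cc(C)c4=O)cc3F)ccnc2cc1OCCCCCC(=O)NO`: 4170 nM
compound 2 `COc1cc2c(Oc3ccc(NC(=O)c4nn(-c5ccc(Cl)c(C(F)(F)F)c5)cc(C)c4=O)cc3)ccnc2cc1OCC(=O)NO`: 1590 nM

In a functional assay on A549 cells (Homo sapiens) for inhibition, read by MTT assay, with a stated time of 72 h (on this read-out higher numbers stand for weaker inhibition and lower numbers for stronger inhibition), compound 1 stands highest of the two, and compound 2 lies lower by more than the usual scatter. Compound 3 `COc1cc2c(Oc3ccc(NC(=O)c4nn(-c5ccccc5)cc(C)c4=O)cc3F)ccnc2cc1OCCCC(=O)NO` awaits measurement. It departs from compound 1 by hydroxycarbamoyl in place of 2-(hydroxycarbamoyl)ethyl on a saturated chain carbon, three bonds along the chain from an oxygen on an aromatic ring: hydroxycarbamoyl in place of 2-(hydroxycarbamoyl)ethyl on a saturated chain carbon. For the measured compounds named here, no measured step isolates this change, and compound 2 at 1590 nM differs from compound 1 in other places too. Only a small fall in this assay, close to the scatter, is expected. The expected step is a 1.4-fold lower number from compound 1 to compound 3 (0.14 log units; within the scatter). Compound 3 is estimated at 3000 nM, with an expected range of 1200 nM to 7500 nM.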

Compound 3, half-maximal inhibitory concentration: 1900 nM
Compound 3: the middle estimate sits 1.6-fold (0.20 log units) above what was measured; low and high end bracket the measured number.
By their numbers in this assay, from the lowest: compounds 2 and 3 (each within the scatter of the next); then compound 1.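

In this assay, for the compounds shown here, going from 5-(hydroxycarbamoyl)pentyl to 3-(hydroxycarbamoyl)propyl on the shared core gives a 2.2-fold lower number from compound 1 to compound 3 (0.34 log units; beyond the scatter) as a modest step, the only single-place reading at this position. On this one pair, the shorter chain gives the lower number, so the longer chain is not required for inhibition at this level. No measured evidence bears on the cause of this step.

From the compounds shown here alone, one step cannot define a trend with chain length, and whether (hydroxycarbamoyl)methyl would continue the fall on this core stays open. Also open, going by these compounds, is how a carboxylic acid or an amine in place of the hydroxycarbamoyl end would read.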